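The compounds below may be only part of what the source reports. "The series", "measured", "known", "first", "only" and "open" are said of these compounds alone.

Working notes on the series. Compound 1 `CC1=C(C(=O)OCC2CC2)C(c2ccoc2)NC(=O)N1` gives 29% in an assay on membranes from CHO cells for displacement of a labelled ligand from adenosine receptor A1 (Homo sapiens), read by scintillation counting, with a stated time of 60 min, tested at 1 uM; a higher number here means more inhibition at the concentration tested (going by the name of the read-out), a lower number less inhibition. Compound 2 `CC1=C(C(=O)OCC2CCC2)C(c2ccoc2)NC(=O)N1` carries the change cyclobutyl in place of cyclopropyl on a saturated chain carbon bound to an oxygen next to a carbonyl group and reaches 46% in this assay, a step of a number 17 percentage points higher from compound 1 to compound 2 (beyond the scatter). Compound 3 `CC1=C(C(=O)OCC2CC2)C(c2cccs2)NC(=O)N1` differs from compound 1 by thiophen-2-yl in place of furan-3-yl on a saturated ring carbon. In this assay compound 3 gives 23%, a step of a number 6 percentage points lower from compound 1 to compound 3 (within the scatter), so compound 1 and compound 3 cannot be told apart on this read-out. Compound 4 `CC1=C(C(=O)OCC2CCC2)C(c2cccs2)NC(=O)N1` is compound 3 with the same change, (cyclobutyl in place of cyclopropyl on a saturated chain carbon bound to an oxygen next to a carbonyl group), made at the same place. Going by the values given here, for compound 4 the step from compound 3 is expected to be a number 17 percentage points higher from compound 3 to compound 4 (beyond the scatter), resting on the single earlier instance of this change, which gave a number 17 percentage points higher from compound 1 to compound 2 (beyond the scatter), applied to the value of compound 3, 23%. The estimate for compound 4 in this assay is 40%, expected to fall between 27% and 53%.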

Compound 4, a percentage reported as inhibition, at one concentration (the size of the read-out at that concentration, not a potency): 39%
For compound 4 the middle estimate is 1 percentage points above the measured one; low and high end bracket the measured number.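

In this assay, cyclobutyl in place of cyclopropyl gives a number 16 percentage points higher from compound 3 to compound 4 (beyond the scatter), and the change carries over between the two cores at the same size: the same change on two cores in this assay, a number 17 percentage points higher (beyond the scatter) from compound 1 to compound 2 and a number 16 percentage points higher (beyond the scatter) from compound 3 to compound 4, 1 percentage points apart, within the scatter of two such steps. Thiophen-2-yl in place of furan-3-yl gives a number 7 percentage points lower from compound 2 to compound 4 (within the scatter), which also repeats on both cores without separating either pair: the same change on two cores in this assay, a number 6 percentage points lower (within the scatter) from compound 1 to compound 3 and a number 7 percentage points lower (within the scatter) from compound 2 to compound 4, 1 percentage points apart, within the scatter of two such steps. This shows the two changes adding up across these four compounds only; it rests on a single read-out at one concentration and gives no potency.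

Still open, on these data alone, is whether the step continues with cyclopentyl or a longer chain on the saturated chain carbon. Also open, as far as these compounds go, is how a phenyl or a pyridine on the saturated ring carbon would read.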